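The compounds below may be only part of what the source reports. "The series", "measured", "known", "first", "only" and "open" are said of these compounds alone.

Working notes on the series. In a functional assay on MCF7 cells (Homo sapiens) for cytotoxicity, read by MTT assay, with a stated time of 24 h (on this read-out higher numbers stand for weaker inhibition and lower numbers for stronger inhibition), compound 1 `c1ccc(CNC(c2ccc[nH]2)c2nnc(-c3ccccc3)o2)cc1` gives 216000 nM, compound 2 `Brc1ccc(-c2nnc(C(NCc3ccccc3)c3ccc[nH]3)o2)cc1` gives 96600 nM and compound 3 `Cc1cccc(-c2nnc(C(NCc3ccccc3)c3ccc[nH]3)o2)c1` gives 480000 nM. The step of a 2.2-fold lower number from compound 1 to compound 2 (0.35 log units; beyond the scatter) comes from bromo in place of hydrogen on an aromatic carbon; the step of a 2.2-fold higher number from compound 1 to compound 3 (0.35 log units; beyond the scatter) comes from methyl in place of hydrogen on an aromatic carbon; between the two substituted analogues the step is a 5.0-fold higher number from compound 2 to compound 3 (0.70 log units; beyond the scatter). Compound 4 `Cc1ccc(CNC(c2ccc[nH]2)c2nnc(-c3ccc(Br)cc3)o2)cc1` is not yet measured; it differs from compound 2 by methyl in place of hydrogen on an aromatic carbon. The same kind of change, methyl in place of hydrogen on an aromatic carbon, was made from compound 1 to compound 3, where it gave a 2.2-fold higher number from compound 1 to compound 3 (0.35 log units; beyond the scatter), though there the place reads meta to a large group and the cut one bond further reads phenyl to 3-methylphenyl, whereas here it reads para to a large group and benzyl to 4-methylbenzyl. The two cores differ by bromo in place of hydrogen on an aromatic carbon. For the measured compounds named here, a step like a 1.7-fold higher number from compound 2 to compound 4 (0.22 log units; within the scatter) is expected from compound 2 to compound 4 in this assay, resting on the earlier methyl step a 2.2-fold higher number from compound 1 to compound 3 (0.35 log units; beyond the scatter) on compound 1, tempered because the place differs and only one example exists. Compound 4 is thus estimated at 160000 nM, between 60000 nM and 420000 nM.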

Compound 4, half-maximal inhibitory concentration: 4300 nM
Compound 4: the middle estimate sits 37-fold (1.57 log units) above what was measured, and the stated range ends above it.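

In this assay the methyl step does not carry from one core to another as a fixed increment: the same change on two cores in this assay, a 2.2-fold higher number (0.35 log units; beyond the scatter) from compound 1 to compound 3 and a 22-fold lower number (1.35 log units; beyond the scatter) from compound 2 to compound 4, 50-fold (1.70 log units) apart, beyond the scatter of two such steps. On the bromo core, 4-methylbenzyl in place of benzyl gives a 22-fold lower number from compound 2 to compound 4 (1.35 log units; beyond the scatter), so this methyl is the largest single change in the series. This does not show that the bromo core alone sets the outcome: the methyl of compound 4 stands on the benzyl group, that of compound 3 on the phenyl group, and a single pair cannot separate core from place.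

On these data alone, whether 4-methylbenzyl on the core of compound 1 gives a step of similar size remains open. Also open, as far as these compounds go, is whether an ethyl, a methoxy or an amine at the same place on the benzyl group would follow the methyl.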